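Swapping bromo for chloro on a phenoxy ring

A few compounds are considered here, and "the series" means these few. Any claim that something is new, unique, unknown or untested is made for them only; others in the source may bear on it.

Compounds measured so far in an assay on isolated protein for inhibition of Dihydrofolate reductase (Homo sapiens), read by spectrophotometry, using NADPH, with stated times of 5 s and 6 min, tested at 5 uM; a higher number here means a stronger effect of the compound at the concentration tested, a lower number a weaker effect:
Compound 1, `NC1=NC2(CCOCC2)N(OCCCOc2ccccc2)C(N)=N1`, gives > 90%, which is a limit of the assay.
Compound 2, `NC1=NC2(CCSCC2)N(OCCCOc2ccc(Br)cc2)C(N)=N1`, gives > 90%, again a limit of the assay.
Compound 3, `NC1=NC2(CCOCC2)N(OCCCOc2cc(Cl)c(Cl)cc2Cl)C(N)=N1`, gives > 90%, also a limit of the assay.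

All three compounds share one core and differ only in the aromatic ring hanging from the ether chain. Because (the limit of > 90% in this assay, at which 3 of the 3 values shown sit), none of the values is a real number, and compound 2 cannot be placed against the others: its reading is only a limit, and so are the two readings beside it. Among the measured compounds shown here, the one comparison between measured compounds is a step that the two limits leave unreadable from compound 1 to compound 3, and with both ends sitting at the limit its size cannot be read.

The next compound, compound 4, `NC1=NC2(CCSCC2)N(OCCCOc2ccc(Cl)cc2)C(N)=N1`, differs from compound 2 in one place: chloro in place of bromo on an aromatic carbon. For the measured compounds named here, no measured step involves a halogen exchange of this kind, so there is nothing to set a size or direction for the change; the only guide is that every phenoxy variant seen so far, with or without halogens, reached the limit.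

The step from compound 2 to compound 4 is therefore expected to be small, a step that the limit leaves unreadable from compound 2 to compound 4, with compound 4 most likely again at the limit. Compound 4 is estimated at 93%, within 80% to 100%.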

Compound 4, a percentage reported as inhibition, at one concentration (the size of the read-out at that concentration, not a potency): > 90%
Compound 4: a limit, no number (the forecaster's own chance of this, stated with the estimate: 80%); the middle value lies beyond the limit too.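

In this assay compound 4 gives > 90%, a limit of the assay. The exchange of bromo for chloro between compound 2 and compound 4 therefore yields no step whose size can be read: the limit of > 90% in this assay, at which 4 of the 4 values shown sit.

Going by these compounds, how these compounds rank against one another, and whether any change on the phenoxy ring alters inhibition at all, stays open.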